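The compounds below may be only part of what the source reports. "The series", "measured", "known", "first", "only" and "open" are said of these compounds alone.

Measured in an ADME assay on L02 cells (Homo sapiens) for cytotoxicity, read by MTT assay; on this read-out lower numbers stand for stronger inhibition and higher numbers for weaker inhibition:

- Compound 1 `COc1ccc(/C=C/C(=O)c2ccc(OC)c3c2OC(C)(C)C=C3)cc1O`: > 10000 nM
- Compound 2 `C#CCOc1cc(/C=C/C(=O)c2ccc(OC)c3c2OC(C)(C)C=C3)ccc1OC`: > 10000 nM
- Compound 3 `COc1ccc(/C=C/C(=O)c2ccc(OC)c3c2OC(C)(C)C=C3)cc1OCCO`: > 10000 nM

Each of these entries is a limit of the assay and not a number. Compound 3 therefore has no exact position, and the same holds for the other two compounds. The whole set sits together: the limit of > 10000 nM in this assay, at which 3 of the 3 values shown sit.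

Compound 4 `COc1ccc(/C=C/C(=O)c2ccc(OC)c3c2OC(C)(C)C=C3)cc1OCCCN(C)C` differs from compound 3 in one place: (dimethylamino)methyl in place of hydroxy on a saturated chain carbon, two bonds along the chain from an oxygen on an aromatic ring. Read one bond further out, 2-hydroxyethoxy gives way to 3-(dimethylamino)propoxy.

Among the measured compounds shown here, three measured steps bear on this change, since all of them alter the same oxygen substituent. They are a step that the two limits leave unreadable from compound 1 to compound 3, a step that the two limits leave unreadable from compound 2 to compound 3 and a step that the two limits leave unreadable from compound 1 to compound 2. None has a readable size, so they offer no measured effect to carry over. For the measured compounds named here, they show only that these changes to the substituent left each compound at the limit.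

Going by the values given here, with no measured step to suggest a shift, the expected change in this assay is no larger than the usual scatter, and its direction is open. The expected step is a step that the limit leaves unreadable from compound 3 to compound 4. For compound 4 the estimated value is 12000 nM. The estimated range for compound 4 runs from 5000 nM to 40000 nM, and a further report of only a limit is the likeliest outcome.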

Compound 4, half-maximal inhibitory concentration: 8600 nM
Compound 4: the middle estimate sits 1.4-fold (0.14 log units) above what was measured; measured number inside the range.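

In this assay compound 4 is the only one of the set that gives a measured number, 8600 nM, so 3-(dimethylamino)propoxy is the only group shown on this oxygen that brings a reading inside the range of the assay. Its steps are an at least 1.1-fold lower number from compound 3 to compound 4 (0.06 log units; that floor lies within the scatter), an at least 1.1-fold lower number from compound 2 to compound 4 (0.06 log units; that floor lies within the scatter) and an at least 1.1-fold lower number from compound 1 to compound 4 (0.06 log units; that floor lies within the scatter); each of these is only a floor, so the change may be larger, but as printed none of them shows a shift beyond the scatter. The steps among compound 1, compound 2 and compound 3 cannot be read, and the true size of all these differences stays unknown, because most of the set rests on a limit and not on a number: the limit of > 10000 nM in this assay, at which 3 of the 4 values shown sit.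

Compound 4 differs from compound 3 in both the length of the chain and the group it carries, so the compounds shown cannot say which of the two matters. A 3-hydroxypropyl group or a 2-(dimethylamino)ethyl group on the same oxygen would separate the two, and a carboxylic acid or a morpholine in place of the dimethylamino group would show whether an amine is needed at all.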